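A few compounds are considered here, and "the series" means these few. Any claim that something is new, unique, unknown or untested is made for them only; others in the source may bear on it.

Measured compounds:
compound 1, `COc1ccc(F)cc1Nc1cc(NC(=O)Nc2c(Cl)cccc2Cl)ncn1`: 38.1%
compound 2, `COc1cc(NC(=O)Nc2cc(Nc3cccc(C(C)(C)C)c3)ncn2)cc(OC)c1`: 13.1%
compound 3, `CC(C)(C)c1ccc(Nc2cc(NC(=O)Nc3c(Cl)cccc3Cl)ncn2)cc1`: 22%

The three compounds were tested in a functional assay on NCI-H520 cells (Homo sapiens) for inhibition, read by MTT assay, with a stated time of 48 h, tested at 10 uM; a higher number here means more inhibition at the concentration tested (going by the name of the read-out), a lower number less inhibition. Within the data shown here, of the three numbers, the one for compound 2 is the smallest. Its gap to compound 3 lies within the usual scatter, so these two cannot be told apart on this evidence. Compound 1 stands beyond the scatter above compound 2.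

Compound 4, `COc1cc(NC(=O)Nc2cc(Nc3ccc(Br)cc3OC)ncn2)cc(OC)c1`, has not yet been measured in this assay. It differs from compound 2 in one place: 4-bromo-2-methoxyphenyl in place of 3-(tert-butyl)phenyl on a nitrogen on an aromatic ring. The rest of the molecule is kept.

Among the measured compounds shown here, no measured pair in this set differs in only one place, so no measured step can be used as a guide for this change. Compound 1 carries a methoxy-bearing aryl group on the corresponding nitrogen and gives the highest number of the three, but its urea part differs as well, so its value cannot be attributed to that group alone. On this basis the step from compound 2 to compound 4 is expected to be small, a number 6.9 percentage points higher from compound 2 to compound 4 (within the scatter), and probably not beyond the scatter. Compound 4 is therefore estimated at 20%, with a range from 5% to 40%.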

Compound 4, a percentage reported as inhibition, at one concentration (the size of the read-out at that concentration, not a potency): 36.1%
Compound 4: middle estimate off by 16.1 percentage points, on the low side, within the range that was stated.
By their numbers in this assay, from the lowest: compounds 2 and 3 (each within the scatter of the next); then compounds 4 and 1 (each within the scatter of the next).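

Among these compounds, the exchange of 3-(tert-butyl)phenyl for 4-bromo-2-methoxyphenyl on a nitrogen on an aromatic ring is the first single change in this set that can be read on its own, and in this assay it gives a number 23 percentage points higher from compound 2 to compound 4 (beyond the scatter) with the rest of the molecule kept. Among the compounds shown here, it shows that the aryl group on this nitrogen can by itself move the read-out beyond the scatter, which the earlier compounds could not show, as each of them differs from the others in more than one place. Nothing measured here accounts for the step.

The entering group brings a bromine and a methoxy group together, so the compounds shown leave open which of the two, or whether only the pair, goes with the higher number, and whether the same exchange would give a similar step with the urea part of compound 1 in place. They also leave open what a morpholine or a carboxylic acid on this aryl group would give at the same nitrogen.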